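Swapping Chloro for Fluoro on a Shared Core

The compounds below may be only part of what the source reports. "The series", "measured", "known", "first", "only" and "open" are said of these compounds alone.

Measured so far:
compound 1, `c1ccc(-c2n[nH]cc2N2CCNCC2)cc1`: 185 nM
compound 2, `Clc1cccc(-c2n[nH]cc2N2CCNCC2)c1`: 109 nM

In an assay on isolated protein for binding affinity to 5-hydroxytryptamine receptor 6 (Homo sapiens) (on this read-out higher numbers stand for weaker inhibition and lower numbers for stronger inhibition), compound 1 gives 185 nM, while compound 2 gives 109 nM. Among the measured compounds shown here, compound 2 sits alongside compound 1 rather than apart from it: the single measured step, a 1.7-fold lower number from compound 1 to compound 2 (0.23 log units; within the scatter), is one the usual scatter covers, so the two numbers are not told apart.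

Compound 3, `Fc1cccc(-c2n[nH]cc2N2CCNCC2)c1`, is not yet measured. It differs from compound 2 by fluoro in place of chloro on an aromatic carbon. For the measured compounds named here, the only step on record, a 1.7-fold lower number from compound 1 to compound 2 (0.23 log units; within the scatter), concerns adding chloro to the bare ring of compound 1, and it was small. Nothing measured involves fluoro at all, so the expectation rests on that one small step: in this assay the move a 1.4-fold higher number from compound 2 to compound 3 (0.14 log units; within the scatter) is expected to stay within the scatter. Compound 3 is therefore estimated at 150 nM, with a likely range from 70 nM to 320 nM.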

Compound 3, inhibition constant: 162 nM
Compound 3: the middle estimate sits 1.1-fold (0.03 log units) below what was measured; the range from low to high includes it.
By their numbers in this assay, from the lowest: compounds 2, 3 and 1 (each within the scatter of the next).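

In this assay the step for fluoro in place of chloro on this aromatic carbon is a 1.5-fold higher number from compound 2 to compound 3 (0.17 log units; within the scatter) and the step for fluoro in place of hydrogen is a 1.1-fold lower number from compound 1 to compound 3 (0.06 log units; within the scatter) so all three steps among these compounds now lie within the scatter. Hydrogen, fluoro and chloro at this one place, meta to a large group, therefore cannot be told apart on these numbers, and swapping one halogen for the other adds no measurable difference. Nothing measured here bears on the reason for this, so no explanation can be offered.

These compounds leave open whether a different kind of group at this place, such as a methoxy group, an amine or a carboxylic acid, would shift the number beyond the scatter. They also leave open whether chloro or fluoro would behave the same way on another carbon of this ring.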